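This account rests on a few compounds, and the source may have more. Where it says the series, first, only, none or still open, it means among the compounds named here.

Compound 2 `COc1cccc(COc2ccccc2OCCNCCOc2c(OC)cccc2OC)c1` gives 8.31 in a functional assay on spleen for antagonist activity at Alpha-1B adrenergic receptor (Rattus norvegicus); a lower number here means a less potent compound, a higher number a more potent compound, by a factor of ten per unit of this negative logarithm. Compound 1 `COc1cccc(OC)c1OCCNCCOc1ccccc1OCc1cccc(C)c1` gives 8.2 in this assay; the two numbers lie within the scatter of each other, as the step of a number 0.11 log units higher from compound 1 to compound 2 (within the scatter) shows. Compound 3 `COc1cccc(OC)c1OCCNCCOc1ccccc1OCc1ccc(OC(C)C)cc1` has not yet been measured in this assay. It differs from compound 2 by 4-isopropoxyphenyl in place of 3-methoxyphenyl on a saturated chain carbon bound to an oxygen on an aromatic ring. Going by the values given here, the only measured step, a number 0.11 log units higher from compound 1 to compound 2 (within the scatter), exchanged one small group for another at the same place and left the number within the scatter; the change to compound 3 both relocates the ether substituent on that ring and enlarges it, and no measured pair covers such a move. The step of a number 0.21 log units lower from compound 2 to compound 3 (within the scatter) is therefore expected to stay within the scatter, with only a slight downward lean because the change is wider than in a number 0.11 log units higher from compound 1 to compound 2 (within the scatter). Compound 3 is thus estimated at 8.1, between 7.5 and 8.7.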

Compound 3, negative logarithm of the antagonist equilibrium constant: 8.62
Compound 3: the middle estimate sits 0.52 log units below what was measured; measured number inside the range.
By their numbers in this assay, from the lowest: compounds 1 and 2 (each within the scatter of the next); then compound 3.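

At the saturated chain carbon bound to an oxygen on an aromatic ring, a change now moves the number beyond the scatter in this assay: 4-isopropoxyphenyl in place of 3-methoxyphenyl gives a number 0.31 log units higher from compound 2 to compound 3 (beyond the scatter), and in place of 3-methylphenyl it gives a number 0.42 log units higher from compound 1 to compound 3 (beyond the scatter). Compound 1 and compound 2 lie within the scatter of each other, so this place did not separate them, whereas 4-isopropoxyphenyl stands modestly above both and its 10 heavy atoms, against 8 in 3-methoxyphenyl, bring no loss. Nothing available bears on the reason for this gain.

The place of the ether on the ring and its size change together here, so 3-isopropoxyphenyl and 4-methoxyphenyl would be needed to tell the two apart. From the compounds shown here alone, how a longer chain such as 4-butoxyphenyl, or an amine such as 4-aminophenyl, would read at this place remains open.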